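Thiocarbamate series: ring amine to butylamino on the thiocarbonyl

This account rests on a few compounds, and the source may have more. Where it says the series, first, only, none or still open, it means among the compounds named here.

Compound 1 `S=C(SCc1nc2ccccc2[nH]1)N1CCCC1` gives 1800 nM in a functional assay on the whole organism for inhibition, with Cicer arietinum as the target, with a stated time of 7 days (on this read-out lower numbers stand for stronger inhibition and higher numbers for weaker inhibition), and compound 2 `S=C(SCc1nc2ccccc2[nH]1)N1CCOCC1` gives 1890 nM in the same assay. Among the measured compounds shown here, the only step seen so far, a 1.1-fold higher number from compound 1 to compound 2 (0.02 log units; within the scatter), is flat, so compound 2 and compound 1 sit within the scatter of each other on the two numbers available. Compound 3 `CCCCNC(=S)SCc1nc2ccccc2[nH]1` differs from compound 2 by butylamino in place of morpholin-4-yl on a thiocarbonyl carbon. For the measured compounds named here, no measured step swaps a ring amine for an open-chain amine, so that flat step is only loosely informative. For compound 3 a number within the scatter of compound 2 is expected, a 1.0-fold higher number from compound 2 to compound 3 (0.00 log units; within the scatter), estimated at 1900 nM with a range of 900 nM to 4000 nM.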

Compound 3, half-maximal inhibitory concentration: 2110 nM
The estimate for compound 3 lay 1.1-fold (0.05 log units) below the measured number, within the range that was stated.
By their numbers in this assay, from the lowest: compounds 1, 2 and 3 (each within the scatter of the next).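

The change from a ring amine to an open-chain amine leaves the read-out in this assay flat, both from the morpholin-4-yl group (a 1.1-fold higher number from compound 2 to compound 3 (0.05 log units; within the scatter)) and from the pyrrolidin-1-yl group (a 1.2-fold higher number from compound 1 to compound 3 (0.07 log units; within the scatter)). On a thiocarbonyl carbon whose other neighbour is sulfur, the ring is therefore not needed for this level of inhibition, and neither is the absence of a hydrogen-bond donor, which the ring-to-ring step could not show. No supporting evidence bears on this result.

Still open, as far as these compounds go, is whether a longer chain such as octylamino, or an aromatic group such as benzylamino, would move the number beyond the scatter.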